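The source may hold more compounds than are shown below. What is called first, only, known or untested is meant among the compounds shown, and "the series" means these compounds.

Compound 1 `COC1=CC(=O)c2c(COc3ccc(N)cc3)c(C)n(C)c2C1=O`: 160 nM
Compound 2 `COC1=CC(=O)c2c(COc3ccc([N+](=O)[O-])cc3F)c(C)n(C)c2C1=O`: 417 nM
Compound 3 `COC1=CC(=O)c2c(COc3c(F)cc(F)cc3F)c(C)n(C)c2C1=O`: 212 nM

These values come from a functional assay on MIA PaCa-2 cells (Homo sapiens) for cytotoxicity, read by MTT assay, with a stated time of 72 h; on this read-out lower numbers stand for stronger inhibition and higher numbers for weaker inhibition. Compound 1 lies within the usual scatter of compound 3, while compound 2 has a higher number, beyond the scatter from compound 1. Compound 4 `COC1=CC(=O)c2c(COc3ccncc3)c(C)n(C)c2C1=O` is still unmeasured. It carries pyridin-4-yl in place of 4-aminophenyl on an oxygen on a saturated carbon. For the measured compounds named here, no measured pair isolates a single change, so the only guide is the range from compound 1 at 160 nM to compound 2 at 417 nM. The expected 1.6-fold higher number from compound 1 to compound 4 (0.19 log units; within the scatter) stays within the scatter in this assay, leaning towards a higher number. For compound 4 the estimated value is 250 nM, with an expected range of 90 nM to 700 nM.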

Compound 4, half-maximal inhibitory concentration: 3270 nM
The estimate for compound 4 lay 13-fold (1.12 log units) below the measured number, outside the stated range (above it).
By their numbers in this assay, from the lowest: compounds 1, 3 and 2 (each within the scatter of the next, the first and the last beyond it); then compound 4.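

In this assay, for the compounds shown here, the group on this oxygen clearly matters: pyridin-4-yl in place of 4-aminophenyl gives a 20-fold higher number from compound 1 to compound 4 (1.31 log units; beyond the scatter) and this is the first single change that can be read. The change does two things at once, since a ring nitrogen enters and the amine with its hydrogen-bond donor leaves. No measured evidence explains the size of this step.

As far as these compounds go, whether the amine's departure or the ring nitrogen's arrival matters more remains open, and a plain phenyl group could separate the two. Pyridin-3-yl would ask whether the place of that nitrogen counts.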